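The source may hold more compounds than are shown below. What is called first, only, known or untested is meant among the compounds shown, and "the series" means these compounds.

Working notes on the series. Compound 1 `Cc1cn(C2CC(N=[N+]=[N-])C(COC(=O)NCCCC(=O)OC(C)(C)C)O2)c(=O)[nH]c1=O` carries the shared core with a carbamate-linked chain ending in tert-butoxycarbonyl. In a functional assay on MT4 cells (Homo sapiens) for cytotoxicity (on this read-out lower numbers stand for higher toxicity in this test and higher numbers for lower toxicity in this test), compound 1 gives > 50000 nM, which is a limit of the assay and not a number. Compound 2 `Cc1cn(C2CC(N=[N+]=[N-])C(COC(=O)OCCCCO)O2)c(=O)[nH]c1=O` is a second member of the set. In this assay compound 2 gives > 50000 nM, again a limit rather than a number. Compound 1 therefore cannot be placed against compound 2 on the values shown: the two values both sit at the limit of > 50000 nM in this assay, at which 2 of the 2 values shown sit.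

Compound 3 `Cc1cn(C2CC(N=[N+]=[N-])C(COC(=O)NCCCN)O2)c(=O)[nH]c1=O` has not been measured. It differs from compound 1 by amino in place of tert-butoxycarbonyl on a saturated chain carbon, three bonds along the chain from an amide-type nitrogen. Within the data shown here, no step between measured compounds is available. With both shown values at the limit, the expected step in this assay, a number no higher from compound 1 to compound 3 (the limit leaves the size open), is none beyond the usual scatter. Compound 3 is expected to give about 50000 nM in this assay, within 20000 nM to 100000 nM, and most probably again only a limit.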

Compound 3, half-maximal cytotoxic concentration: > 50000 nM
Compound 3: a limit, no number (the forecaster's own chance of this, stated with the estimate: 80%); the middle value sits exactly at the limit.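

In this assay compound 3 gives > 50000 nM, a limit of the assay and not a number. Among these compounds, no step from compound 1 or compound 2 to compound 3 can be read. The compounds shown leave open whether amino in place of tert-butoxycarbonyl changes toxicity in this test at all.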